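The source may hold more compounds than are shown below. What is called first, only, known or untested is meant among the compounds shown, and "the series" means these compounds.

Of the compounds shown here, three sharing one core have been tested in a functional assay on HeLa cells (Homo sapiens) for antiproliferative activity, read by MTT assay, with a stated time of 24 h; on this read-out lower numbers stand for stronger inhibition and higher numbers for weaker inhibition. Compound 1 `O=[N+]([O-])c1ccccc1CSc1nnc(-c2ccc3c(c2)OCCO3)n1-c1ccccc1` gives 69800 nM. Compound 2 `O=[N+]([O-])c1ccc(CSc2nnc(-c3ccc4c(c3)OCCO4)n2-c2ccccc2)cc1` gives 36200 nM, and compound 3 `Clc1ccccc1CSc1nnc(-c2ccc3c(c2)OCCO3)n1-c1ccccc1` gives 29000 nM. Compound 1 therefore sits at the top of the three numbers, with a 1.9-fold lower number from compound 1 to compound 2 (0.29 log units; within the scatter) and a 2.4-fold lower number from compound 1 to compound 3 (0.38 log units; beyond the scatter).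

Compound 4 `COc1cccc(CSc2nnc(-c3ccc4c(c3)OCCO4)n2-c2ccccc2)c1` has not yet been measured. It differs from compound 1 in one place: 3-methoxyphenyl in place of 2-nitrophenyl on a saturated chain carbon bound to a sulfur.

Among the compounds with values here, two measured steps bear on this change. The first, a 1.9-fold lower number from compound 1 to compound 2 (0.29 log units; within the scatter), keeps a nitro group but puts 4-nitrophenyl in place of 2-nitrophenyl. The second, a 2.4-fold lower number from compound 1 to compound 3 (0.38 log units; beyond the scatter), takes the nitro group away altogether and is the larger of the two. The change to compound 4 also removes the nitro group, so a modest lowering of the number, of about the size seen in those two steps, is expected: a 2.0-fold lower number from compound 1 to compound 4 (0.30 log units; within the scatter). Compound 4 is thus estimated to give 35000 nM in this assay, within a range from 15000 nM to 80000 nM.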

Compound 4, half-maximal inhibitory concentration: > 100000 nM
Compound 4: a limit, no number; the forecaster's own chance of this, stated with the estimate: 5%; at least 2.8-fold (0.45 log units) between middle value and limit.
By their numbers in this assay, from the lowest: compounds 3, 2 and 1 (each within the scatter of the next, the first and the last beyond it). At a limit, above all of these: compound 4.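

In this assay compound 4 reads > 100000 nM, which is a limit of the assay and not a number. Removing the nitro group therefore does not by itself lower the number, since 3-methoxyphenyl on this saturated chain carbon bound to a sulfur gives an at least 3.4-fold higher number from compound 3 to compound 4 (0.53 log units; beyond the scatter), and also an at least 2.7-fold higher number from compound 2 to compound 4 (0.44 log units; beyond the scatter), so the group placed here can push the number up as well as down. The remaining step, an at least 1.4-fold higher number from compound 1 to compound 4 (0.15 log units; that floor lies within the scatter), has a floor within the scatter, so this limit does not separate that pair.

From the compounds shown here alone, whether 2-methoxyphenyl or 4-methoxyphenyl would behave like 3-methoxyphenyl stays open, so the methoxy group cannot yet be told apart from its place on the ring. Going by these compounds, what an amine or a carboxylic acid on this phenyl ring would do also stays open.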